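The source may hold more compounds than are shown below. What is called first, only, known or untested is meant among the compounds shown, and "the series" means these compounds.

In a functional assay on MCF7 cells (Homo sapiens) for cytotoxicity, read by MTT assay, with a stated time of 48 h (a lower number here means a stronger inhibitor, a higher number a weaker inhibitor), compound 1 `CCN(CC)C(=S)SC(CC(=O)c1ccccc1)c1ccccc1` gives 17000 nM. Compound 3 `CCN(CC)C(=S)SC(CC(=O)c1ccccc1)c1ccccc1OC` gives 16000 nM, and the step of a 1.1-fold lower number from compound 1 to compound 3 (0.03 log units; within the scatter) places the two level with each other, at the weak end of the three numbers. Compound 2 `CCN(CC)C(=S)SC(CC(=O)c1ccccc1)c1ccc(Br)cc1` stands well apart at 80 nM, reached by the step of a 210-fold lower number from compound 1 to compound 2 (2.33 log units; beyond the scatter), where bromo takes the place of hydrogen on an aromatic carbon. The step of a 200-fold higher number from compound 2 to compound 3 (2.30 log units; beyond the scatter) spans the same gap from the other side.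

Compound 4 `CCN(CC)C(=S)SC(CC(C)=O)c1ccccc1` changes a different part of compound 1: methyl in place of phenyl on a carbonyl carbon. In words, methyl replaces phenyl on a carbonyl carbon, which turns benzoyl into acetyl. Among the measured compounds shown here, none of the measured steps touches that carbonyl carbon, so they bear on this change only indirectly. The step of a 210-fold lower number from compound 1 to compound 2 (2.33 log units; beyond the scatter) shows that a single change can move the number a long way in this small set, while the step of a 1.1-fold lower number from compound 1 to compound 3 (0.03 log units; within the scatter) shows that another can leave it in place. The data give no direction for the new change, so no shift beyond the scatter is expected, though the uncertainty remains wide. The expected step is a 1.2-fold higher number from compound 1 to compound 4 (0.07 log units; within the scatter). For compound 4 the estimated value is 20000 nM, with an expected range from 7000 nM to 60000 nM.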

Compound 4, half-maximal inhibitory concentration: 23000 nM
Estimate against measurement, compound 4: 1.2-fold (0.06 log units) below; the range from low to high includes it.
By their numbers in this assay, from the lowest: compound 2; then compounds 3, 1 and 4 (each within the scatter of the next).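

In this assay, the step of a 1.4-fold higher number from compound 1 to compound 4 (0.13 log units; within the scatter) leaves the two compounds level, so on this carbonyl carbon, benzoyl and acetyl cannot be told apart in this assay. Among the compounds shown here, the earlier steps all concerned the aromatic ring on the saturated chain carbon, and this is the first reading from the other end of the molecule: with that ring unsubstituted, the phenyl on the carbonyl carbon, with its six-membered aromatic ring of carbon only, can give way to a single methyl without a shift beyond the scatter. No measurement is available that would explain why the two compounds read alike.

The compounds shown leave open whether this holds in the much stronger setting of compound 2, at 80 nM, since the exchange of phenyl for methyl is shown only on the core of compound 1. They also leave open what other groups on this carbonyl carbon would do, such as a longer chain like propyl, a substituted phenyl like 4-bromophenyl, or an amine, which would turn the ketone into an amide.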